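Taking the methoxy off a weak antiproliferative compound

This account rests on a few compounds, and the source may have more. Where it says the series, first, only, none or still open, it means among the compounds named here.

Among the measured compounds shown here, in a functional assay on A549 cells (Homo sapiens) for antiproliferative activity, read by MTT assay, with a stated time of 48 h (a higher number here means a weaker inhibitor, a lower number a stronger inhibitor), compound 2 `COc1cccc(-c2nn(-c3ccccc3)cc2C(Nc2nc3ccc(OC)cc3s2)c2c(O)ccc3ccccc23)c1` gives 88100 nM as the higher of the two numbers so far, and the only neighbour on this read-out is compound 1 `COc1ccc2nc(NC(c3cn(-c4ccccc4)nc3-c3ccc(Cl)cc3)c3c(O)ccc4ccccc34)sc2c1` at 34500 nM. Compound 3 `COc1ccc2nc(NC(c3cn(-c4ccccc4)nc3-c3ccccc3)c3c(O)ccc4ccccc34)sc2c1` has hydrogen in place of methoxy on an aromatic carbon and so carries phenyl where compound 2 carries 3-methoxyphenyl. For the measured compounds named here, one measured step bears on this change, namely a 2.6-fold higher number from compound 1 to compound 2 (0.41 log units; beyond the scatter) with 3-methoxyphenyl in place of 4-chlorophenyl on an aromatic carbon. Going by the values given here, that step is modest and beyond the scatter, but no measured compound yet holds the plain phenyl. A modest move toward a lower number is therefore expected in this assay, though one within the scatter remains possible. The estimate means an expected 1.8-fold lower number from compound 2 to compound 3 (0.25 log units; within the scatter) in this comparison. Compound 3 is estimated at 50000 nM with a range from 22000 nM to 100000 nM expected.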

Compound 3, half-maximal inhibitory concentration: 44600 nM
Beside the measured number, compound 3's estimate is 1.1-fold (0.05 log units) above it; the range from low to high includes it.
By their numbers in this assay, from the lowest: compounds 1, 3 and 2 (each within the scatter of the next, the first and the last beyond it).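

With hydrogen in place of methoxy, the result is a 2.0-fold lower number from compound 2 to compound 3 (0.30 log units; within the scatter) in this assay, and with hydrogen in place of chloro it is a 1.3-fold higher number from compound 1 to compound 3 (0.11 log units; within the scatter). Compound 3 therefore cannot be separated from either neighbour, although compound 1 and compound 2 lie beyond the scatter of each other, so neither the methoxy nor the chloro has yet shown a measurable difference from plain hydrogen on this ring. No data given here explain why these numbers fall as they do.

From the compounds shown here alone, whether an amine or a carboxylic acid on this ring would give a step beyond the scatter from compound 3 remains open. So does whether any group here could bring the series far below the high numbers seen so far.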